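The source may hold more compounds than are shown below. What is called first, only, known or untested is meant among the compounds shown, and "the series" means these compounds.

Three compounds share one core, a sulfonamide whose chain ends in an amine carrying an aromatic arm. Compound 1 `O=S(=O)(NCCCCNCc1ccc(Br)cc1)c1cc(C(F)(F)F)cc(C(F)(F)F)c1` in a functional assay on HPAC cells (Homo sapiens) for inhibition, read by MTT assay, with a stated time of 72 h (a lower number here means a stronger inhibitor of growth, a higher number a weaker inhibitor of growth), gives 2000 nM. Compound 2 `CN(CCCNS(=O)(=O)c1cc(C(F)(F)F)cc(C(F)(F)F)c1)Cc1ccccc1` in this assay gives 30000 nM. Compound 3 `O=S(=O)(NCCCNCc1cccc2ccccc12)c1cc(C(F)(F)F)cc(C(F)(F)F)c1` in this assay gives 2400 nM, the second highest of the three numbers; its gap to compound 1 lies within the usual scatter, while its gap to compound 2 lies beyond it. For the measured compounds named here, the only step between measured compounds that differ in one place is a 15-fold higher number from compound 1 to compound 2 (1.18 log units; beyond the scatter), but that step alters the amine itself as well as the arm, so it bears only loosely on a change of arm alone.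

Compound 4 `O=S(=O)(NCCCNCc1cccc(Cl)c1)c1cc(C(F)(F)F)cc(C(F)(F)F)c1` has not yet been measured. It differs from compound 3 in one place: 3-chlorophenyl in place of naphthalen-1-yl on a saturated chain carbon bound to an amine nitrogen. The closest guide is that compound 1, with a 4-bromobenzyl arm, and compound 3, with a (naphthalen-1-yl)methyl arm, sit within the scatter of each other, which suggests that swapping one aromatic arm for another of this kind moves the number little. Compound 4 is therefore expected to give about 3000 nM, within a range from 1200 nM to 8000 nM. The step of a 1.3-fold higher number from compound 3 to compound 4 (0.10 log units; within the scatter) that this estimate implies is expected to stay within the scatter.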

Compound 4, concentration for 50% growth inhibition: 2700 nM
Compound 4: the middle estimate sits 1.1-fold (0.05 log units) above what was measured; low and high end bracket the measured number.
By their numbers in this assay, from the lowest: compounds 1, 3 and 4 (each within the scatter of the next); then compound 2.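

In this assay, 3-chlorophenyl in place of naphthalen-1-yl on a saturated chain carbon bound to an amine nitrogen gives a 1.1-fold higher number from compound 3 to compound 4 (0.05 log units; within the scatter), so at this position one chlorine-bearing aromatic ring matches the two aromatic rings of naphthalen-1-yl, despite having fewer heavy atoms. The comparison with the 4-bromobenzyl arm and its longer chain, a 1.4-fold higher number from compound 1 to compound 4 (0.13 log units; within the scatter), also stays within the scatter, whereas an 11-fold lower number from compound 2 to compound 4 (1.05 log units; beyond the scatter) is a large step, though it changes both the methyl on the amine nitrogen and the chlorine on the ring, so neither change can be credited with it alone. Nothing measured here explains why these different arms give matching numbers.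

The compounds shown leave open whether the large gap to compound 2 belongs to the methyl on its amine or to its ring lacking a halogen, which an unsubstituted benzyl arm on an amine without that methyl would help to separate. Also open, going by these compounds, is whether the match extends to an arm with a pyridine ring or one carrying a carboxylic acid.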